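The compounds below may be only part of what the source reports. "The series", "measured", "known", "first", "only" and "open" are said of these compounds alone.

Working notes on the series. In a functional assay on SH-SY5Y cells (Homo sapiens) for antiproliferative activity, read by MTT assay, with a stated time of 48 h (a higher number here means a weaker inhibitor of growth, a lower number a stronger inhibitor of growth), compound 1 `COc1ccccc1OCCNc1cnn(Cc2ccc(OC)c(OCC3CC3)c2)c(=O)c1Cl` gives 37900 nM. Compound 3 `COc1ccc(Cn2ncc(NCCOc3ccccc3OC)c(Cl)c2=O)cc1OC` gives 33100 nM, which places it within the scatter of compound 1. Compound 2 `COc1ccccc1OCCNc1ccc(=O)n(Cc2ccc(OC)c(OC3CCCC3)c2)n1` reads > 100000 nM, which is a limit of the assay and not a number. Compound 1 therefore has one close numerical neighbour and no wider spread of numbers around it.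

The next compound is compound 4 `COc1ccccc1OCCNc1cnn(Cc2ccc(OC(F)F)c(OCC3CC3)c2)c(=O)c1Cl`, which differs from compound 1 as follows: difluoromethyl in place of methyl on an oxygen on an aromatic ring. This places difluoromethyl in place of methyl on an oxygen on an aromatic ring, so methoxy goes to difluoromethoxy.

Among the compounds with values here, no measured step makes this change. Within the data shown here, the only measured step available, a 1.1-fold lower number from compound 1 to compound 3 (0.06 log units; within the scatter), concerns a different group, so it is indirect evidence at best. It shows that one change to the substituents of compound 1 left this assay within the scatter, but it cannot set a direction for the new change. No shift beyond the scatter is therefore expected, and the estimated step is a 1.2-fold lower number from compound 1 to compound 4 (0.07 log units; within the scatter). From the compounds shown here alone, the range is kept wide because the change itself is untested here. Compound 4 is expected at 32000 nM, with an estimated range of 13000 nM to 80000 nM.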

Compound 4, concentration for 50% growth inhibition: > 100000 nM
Compound 4: a limit, no number; the forecaster's own chance of this, stated with the estimate: 12%; middle value at least 3.1-fold (0.49 log units) away from the limit.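

Difluoromethyl in place of methyl on an oxygen on an aromatic ring gives an at least 2.6-fold higher number from compound 1 to compound 4 (0.42 log units; beyond the scatter). Within the data shown here, this shows that this assay responds to a change at this oxygen, whereas the one earlier measured step, a 1.1-fold lower number from compound 1 to compound 3 (0.06 log units; within the scatter), concerned a different group and did not move the reading beyond the scatter. The reading of compound 4 is a limit of the assay and not a number, so the step fixes a direction towards weaker inhibition of growth and only a minimum size: the limit of > 100000 nM in this assay, at which 2 of the 4 values shown sit.

The compounds shown leave open whether a group other than methyl or difluoromethyl on this oxygen, such as ethyl, trifluoromethyl or a longer chain, would keep a measurable number in this assay, and so whether the loss follows from the fluorine atoms or from any enlargement of the methyl group. They also leave open whether methoxy to difluoromethoxy would shift the number in the same direction on compound 3, which carries a different group on its other ring oxygen.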